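The source may hold more compounds than are shown below. What is called first, only, known or untested is meant among the compounds shown, and "the series" means these compounds.

Among the compounds with values here, compound 2 `Cc1cccc(Cn2c(CN3CCN(C(=O)c4ccco4)CC3)nc3ccccc32)c1` stands highest of the two numbers so far in an assay on isolated protein for inhibition of aldehyde dehydrogenase 1A1 (Homo sapiens), read by spectrophotometry, tested at 10 uM (a lower number here means less inhibition, a higher number more inhibition at the concentration tested (going by the name of the read-out)), where compound 2 gives 73.2%. Within the data shown here, its only measured neighbour is compound 1 `Cc1cccc(Cn2c(CN3CCN(C(=O)c4ccc(Cl)cc4)CC3)nc3ccccc32)c1`, which in this assay gives 23.2%. Among the measured compounds shown here, the one step available, a number 50 percentage points higher from compound 1 to compound 2 (beyond the scatter), is large and well beyond the scatter, and it rests on the exchange of 4-chlorophenyl for furan-2-yl on the carbonyl carbon.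

Compound 3 `Cc1cccc(Cn2c(CN3CCN(C(=O)c4ccc(F)cc4)CC3)nc3ccccc32)c1` is reached from compound 2 by the change (4-fluorophenyl in place of furan-2-yl on a carbonyl carbon). For the measured compounds named here, this bears directly on the measured step: 4-fluorophenyl, like the 4-chlorophenyl of compound 1, is a six-membered aromatic ring of carbon only with no hydrogen-bond acceptor, so the step is expected to run the other way from the one into compound 2, though with a different halogen the size is uncertain. Compound 3 is therefore estimated to give 35% in this assay, within 15% to 65%, which means an expected step of a number 38.2 percentage points lower from compound 2 to compound 3 (beyond the scatter).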

Compound 3, a percentage reported as inhibition, at one concentration (the size of the read-out at that concentration, not a potency): 27.1%
For compound 3 the middle estimate is 7.9 percentage points above the measured one, within the range that was stated.
By their numbers in this assay, from the lowest: compounds 1 and 3 (each within the scatter of the next); then compound 2.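

In this assay, the drop seen with 4-chlorophenyl on the carbonyl carbon proves not to be confined to that one group, since 4-fluorophenyl in place of furan-2-yl gives a number 46.1 percentage points lower from compound 2 to compound 3 (beyond the scatter) and so again stands far from the furan-2-yl compound. Fluoro in place of chloro on an aromatic carbon gives a number 3.9 percentage points higher from compound 1 to compound 3 (within the scatter) and thus leaves the two halogenated phenyl groups indistinguishable here, so that among these three compounds the large difference lies between furan-2-yl and both of them. Nothing available explains why furan-2-yl stands apart from the two halogenated phenyl groups.

The compounds shown do not tell whether the higher inhibition belongs to the oxygen of furan-2-yl or to a five-membered aromatic ring as such, which thiophen-2-yl on the same carbonyl carbon would separate. They also leave open whether the halogen matters at all, a question for plain phenyl at this place.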